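A few compounds are considered here, and "the series" means these few. Any claim that something is new, unique, unknown or untested is made for them only; others in the source may bear on it.

Measured: compound 1 `N#CC1=C(NC(=O)C2CC2)N(c2ccc(S(N)(=O)=O)cc2)C2=C(C(=O)CCC2)C1c1ccc(Cl)cc1Cl`, 40%; compound 2 `NC(=O)C1=C(N)N(c2ccc(S(N)(=O)=O)cc2)C2=C(C(=O)CCC2)C1c1ccc(Cl)cc1Cl`, 40%.

In a functional assay on Ehrlich cells (Mus musculus) for cytotoxicity, read by trypan blue exclusion, with a stated time of 2 h, tested at 50 ug/mL (on this read-out higher numbers stand for a stronger effect at the one concentration tested and lower numbers for a weaker effect), compound 1 gives 40% and compound 2 gives 40%; the two stand level at the digits shown, within the scatter, so compound 1 sits with its nearest neighbour and no spread is yet visible across the measured pair. Compound 3 `CN(C)c1ccc(/C=N/C2=C(C#N)C(c3ccc(Cl)cc3Cl)C3=C(CCCC3=O)N2c2ccc(S(N)(=O)=O)cc2)cc1` remains to be measured in this assay. It differs from compound 1 by a group of 11 heavy atoms (9 carbon, 2 nitrogen; one six-membered aromatic ring of carbon only) in place of a group of 6 heavy atoms (4 carbon, 1 nitrogen, 1 oxygen; one three-membered non-aromatic ring of carbon only), on a double-bonded ring carbon. For the measured compounds named here, no step between measured compounds is known here, so the size of any effect is open; a change of this kind is expected to stay near the scatter, with no direction favoured. Compound 3 is therefore estimated at 40%, between 20% and 60%, which amounts to an expected step of no change at the digits printed from compound 1 to compound 3 (within the scatter).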

Compound 3, a percentage reported as activity, at one concentration (the size of the read-out at that concentration, not a potency): 30%
Compound 3: middle estimate off by 10 percentage points, on the high side; low and high end bracket the measured number.
By their numbers in this assay, from the lowest: compounds 3, 1 and 2 (each within the scatter of the next).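

In this assay, replacing the (cyclopropylcarbonyl)amino group on the double-bonded ring carbon with the group of 11 heavy atoms gives a number 10 percentage points lower from compound 1 to compound 3 (within the scatter). This position therefore carries a group with a six-membered aromatic ring of carbon only and 0 hydrogen-bond donors without a step beyond the scatter, so the amide hydrogen of compound 1 is not shown to matter here. No measurement on hand explains this step. From the compounds shown here alone, how a morpholine or a straight hexyl chain at this position would read remains open, as does any reading at other concentrations.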